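Removing one methoxy from the carbonyl-side aryl of compound 1

This account rests on a few compounds, and the source may have more. Where it says the series, first, only, none or still open, it means among the compounds named here.

Compound 1 `COc1ccc(C(=O)/C=C/c2cc(-c3cc(OC)c(OC)c(OC)c3)n3nc(-c4ccccc4)cc3n2)cc1OC` is tested in a functional assay on A549 cells (Homo sapiens) for antiproliferative activity, read by MTT assay, with a stated time of 24 h (a lower number here means a stronger inhibitor, a higher number a weaker inhibitor), where compound 1 gives 17800 nM. Among the three compounds measured so far it sits second highest: compound 3 `COc1ccc(-c2cc(C(=O)/C=C/c3ccccc3)nc3cc(-c4ccccc4)nn23)cc1OC` gives 18600 nM, a gap within the scatter, while compound 2 `COc1ccc(C(=O)/C=C/c2cc(-c3ccc(OC)c(OC)c3)n3nc(-c4ccccc4)cc3n2)cc1OC` gives 3900 nM, the only value clearly apart from the rest.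

Compound 4 `COc1ccc(C(=O)/C=C/c2cc(-c3cc(OC)c(OC)c(OC)c3)n3nc(-c4ccccc4)cc3n2)cc1` differs from compound 1 by hydrogen in place of methoxy on an aromatic carbon. Seen one bond further out, the 3,4-dimethoxyphenyl attached to the carbonyl becomes a 4-methoxyphenyl.

Going by the values given here, the single measured step of the same kind is a 4.6-fold lower number from compound 1 to compound 2 (0.66 log units; beyond the scatter), where the change sits at a different place in the molecule, on the other aryl ring. It shows that losing one methoxy can lower the number by a modest amount, but whether the same holds at the carbonyl-side aryl is not shown by any measured pair. The expectation for compound 4 is therefore a change of about the same size or smaller, toward a lower number, with a real chance of no step beyond the scatter, i.e. a 1.8-fold lower number from compound 1 to compound 4 (0.25 log units; within the scatter) is expected.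

Compound 4 is estimated at 10000 nM, with a range from 3000 nM to 30000 nM.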

Compound 4, half-maximal inhibitory concentration: 14600 nM
The estimate for compound 4 lay 1.5-fold (0.16 log units) below the measured number; the range from low to high includes it.
By their numbers in this assay, from the lowest: compound 2; then compounds 4, 1 and 3 (each within the scatter of the next).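

In this assay, replacing (3,4-dimethoxyphenyl)carbonyl with (4-methoxyphenyl)carbonyl gives a 1.2-fold lower number from compound 1 to compound 4 (0.09 log units; within the scatter), so on the carbonyl-side aryl this methoxy, ortho to a methoxy group, can be replaced by hydrogen with no step beyond the scatter. The same kind of replacement on the other aryl ring gives a 4.6-fold lower number from compound 1 to compound 2 (0.66 log units; beyond the scatter), so within these two steps, hydrogen in place of methoxy does not read the same on both rings: the step is beyond the scatter on the other aryl ring and within it on the carbonyl-side aryl. No measurement shown here bears on why the two places differ.

Still open is whether the flat result at this place would hold on the background of compound 2, where the other aryl ring already carries one methoxy fewer, since the two replacements are not shown together in one molecule. Also open, as far as these compounds go, is how the number would respond to an amine, a carboxylic acid or a longer alkoxy chain on this same aromatic carbon, as hydrogen and methoxy are the only two substituents seen there so far.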